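The compounds below may be only part of what the source reports. "The series", "measured", "known", "first", "only" and "open" are said of these compounds alone.

Measured set in an ADME assay on WI-38 cells (Homo sapiens) for cytotoxicity, read by MTT assay, with a stated time of 72 h; a higher number here means a weaker inhibitor, a lower number a stronger inhibitor:
Compound 1, `C#Cc1cccc(NC(=O)CCc2cccc3c2B(O)OC3)c1`, reports only the assay limit, > 100000 nM.
Compound 2, `C#Cc1ccccc1NC(=O)CCc1cccc2c1B(O)OC2`, gives 18000 nM.
Compound 3, `O=C(CCc1cccc2c1B(O)OC2)Nc1ccccc1-c1ccccc1`, gives 77000 nM.

Compound 4, `O=C(CCc1cccc2c1B(O)OC2)Nc1cccc(-c2ccccc2)c1`, is not yet measured in this assay.

The change from compound 2 to compound 3 is phenyl in place of ethynyl on an aromatic carbon, and it gave a 4.3-fold higher number from compound 2 to compound 3 (0.63 log units; beyond the scatter). The change from compound 1 to compound 4 is the same kind of change, (phenyl in place of ethynyl on an aromatic carbon); the places differ in that the entering phenyl stands meta to a large group in compound 4 but ortho to a large group in compound 3. The difference between the cores of compound 1 and compound 2 is not broken down here. Compound 1 sits at the limit of > 100000 nM in this assay, at which 1 of the 3 values shown sits, so a step in the direction of a 4.3-fold higher number from compound 2 to compound 3 (0.63 log units; beyond the scatter) would keep compound 4 beyond reach of a number. Compound 4 is expected to show a step that the limit leaves unreadable from compound 1 to compound 4 in this assay, most likely reported as a limit. Compound 4 is estimated at 150000 nM, between 50000 nM and 500000 nM.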

Compound 4, half-maximal inhibitory concentration: 12000 nM
The estimate for compound 4 lay 13-fold (1.10 log units) above the measured number; the measured number lies below the stated range.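

In this assay, phenyl in place of ethynyl gives an at least 8.3-fold lower number from compound 1 to compound 4 (0.92 log units; beyond the scatter), so the direction of this change does not carry from one core to the other: the same change on two cores in this assay, a 4.3-fold higher number (0.63 log units; beyond the scatter) from compound 2 to compound 3 and an at least 8.3-fold lower number (0.92 log units; beyond the scatter) from compound 1 to compound 4, at least 35-fold (1.55 log units) apart, beyond the scatter of two such steps. The value of compound 1, > 100000 nM, is a limit of the assay and not a number: the limit of > 100000 nM in this assay, at which 1 of the 4 values shown sits. With one pair on each core, the data do not show whether the opposite directions follow the place of the change on the ring or some other difference between the cores, and they give no rule for a further core.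

Only ethynyl and phenyl are compared here. From the compounds shown here alone, whether an amine or a carboxylic acid in place of either group would follow one of these two directions remains open.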